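The source may report more compounds than this note shows. Statements on the series, on what has been measured and on what is new or still open speak of the compounds shown alone.

Of the compounds shown here, three have so far been tested in a functional assay on A549 cells (Homo sapiens) for inhibition, read by XTT assay, with a stated time of 48 h; a lower number here means a stronger inhibitor, a higher number a weaker inhibitor. Compound 1 `CCC(/C=C(\COC(C)=O)C(=O)c1ccc(OC)cc1)CC` gives > 100000 nM, which is a limit of the assay rather than a number. Compound 2 `COc1ccc(C(=O)/C(=C/c2ccc(C(F)(F)F)cc2)CC(C)C)cc1` gives > 100000 nM, again a limit of the assay and not a number. For the measured compounds named here, compound 3 `C=C(C(=O)c1ccc(OC)cc1)C(OC(C)=O)c1c(F)c(F)c(F)c(F)c1F` is the only compound with a measured number, giving 14800 nM in this assay. Going by the values given here, the other two values sit at the limit of > 100000 nM in this assay, at which 2 of the 3 values shown sit, so compound 3 is the one compound here with a readable inhibitory concentration. Compound 4 `C=C(C(=O)c1ccc(OC)cc1)C(OC(=O)c1ccccc1)c1c(F)c(F)c(F)c(F)c1F` differs from compound 3 in a single place: phenyl in place of methyl on a carbonyl carbon, that is, acetyl to benzoyl, or acetoxy to benzoyloxy. No pair of measured compounds shows this change, so there is no measured step to lean on, and no cause can be given. The expected step in this assay is a 1.5-fold lower number from compound 3 to compound 4 (0.17 log units; within the scatter), a shift not clearly beyond the usual scatter. Compound 4 is accordingly estimated at 10000 nM, within a range from 3000 nM to 40000 nM.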

Compound 4, half-maximal inhibitory concentration: 32100 nM
Compound 4: middle estimate off by 3.2-fold (0.51 log units), on the low side, within the range that was stated.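

In this assay, for the compounds shown here, the change from methyl to phenyl on a carbonyl carbon, which turns acetoxy into benzoyloxy, gives a 2.2-fold higher number from compound 3 to compound 4 (0.34 log units; beyond the scatter), the first step that can be read here. The position therefore responds to this change, though only modestly, with the benzoyloxy compound the weaker inhibitor of the pair. Both compounds still give readable numbers, so phenyl at this place does not push compound 4 to the limit of the assay reached by the two other compounds: the limit of > 100000 nM in this assay, at which 2 of the 4 values shown sit.

This single pair gives no reason for the step and cannot show whether it would hold on another core. It also leaves open how a longer chain or an amine on this carbonyl carbon would compare with methyl and phenyl.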